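Swapping a Carbon Chain for a Nitrogen-Linked Group

A few compounds are considered here, and "the series" means these few. Any claim that something is new, unique, unknown or untested is made for them only; others in the source may bear on it.

Measured compounds:
compound 1, `CCc1nc(-c2ccc(Cl)cc2Cl)c(CC)nc1SC(C)CC`: 0.0683 h
compound 2, `CCc1nc(-c2ccc(Cl)cc2Cl)c(CC)nc1CC(CC)CC`: 0.0417 h

In an in vitro ADME assay on microsomes (Rattus norvegicus) for metabolic stability (on this read-out lower numbers stand for a shorter-lived compound and higher numbers for a longer-lived compound), compound 1 gives 0.0683 h and compound 2 gives 0.0417 h. Among the measured compounds shown here, the one known step, a 1.6-fold lower number from compound 1 to compound 2 (0.21 log units; within the scatter), means the two values cannot be told apart. Compound 3, `CCc1nc(N(CC2CC2)CC2CC2)c(CC)nc1-c1ccc(Cl)cc1Cl`, carries the change (bis(cyclopropylmethyl)amino in place of 2-ethylbutyl on an aromatic carbon). For the measured compounds named here, only that step bears on it, and it was small, so no step beyond the scatter is expected; the estimate for compound 3 is therefore 0.05 h, between 0.02 h and 0.12 h, a step of a 1.2-fold higher number from compound 2 to compound 3 (0.08 log units; within the scatter) that is expected to stay close to compound 2.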

Compound 3, half-life: < 0.0167 h
Compound 3 ended at the assay's limit (the forecaster's own chance of this, stated with the estimate: 5%); middle value at least 2.9-fold (0.47 log units) away from the limit.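

In this assay compound 3 gives < 0.0167 h, which is a limit of the assay and not a number. Unlike the earlier swap at this position, the change to bis(cyclopropylmethyl)amino gives steps beyond the scatter: an at least 2.4-fold lower number from compound 2 to compound 3 (0.39 log units; beyond the scatter), and an at least 4.0-fold lower number from compound 1 to compound 3 (0.61 log units; beyond the scatter). The half-life therefore does respond to the group at this position, though the true size of both steps stays unknown: the limit of < 0.0167 h in this assay, at which 1 of the 3 values shown sits.

Still open, on these data alone, is whether the ring nitrogen-linked amine itself or its cyclopropylmethyl groups go with this drop. A diethylamino group at the same place could help separate the two.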